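Swapping Aryl Substitution on a Shared Core

A few compounds are considered here, and "the series" means these few. Any claim that something is new, unique, unknown or untested is made for them only; others in the source may bear on it.

Measured compounds:
Compound 1 `COc1cc(/C=C/C(=O)c2cccc(-n3cc(-c4ccc(Cl)cc4)[nH]c3=O)c2)cc(OC)c1OC` gives "not active" (no number reported) in a functional assay on CAKI-1 cells (Homo sapiens) for inhibition; on this read-out lower numbers stand for stronger inhibition of growth and higher numbers for weaker inhibition of growth.
Compound 2 `COc1ccc(-c2cn(-c3cccc(C(=O)/C=C/c4ccc(O)c(OC)c4)c3)c(=O)[nH]2)cc1` gives 4990 nM in this assay.

Among the compounds with values here, compound 2 stands as the only entry with a number in this assay; compound 1 is reported without a single number, so no step between the two can be sized. Compound 3 `COc1ccc(-c2cn(-c3cccc(C(=O)/C=C/c4cc(OC)c(OC)c(OC)c4)c3)c(=O)[nH]2)cc1` is the unmeasured partner of compound 2. The change is 3,4,5-trimethoxyphenyl in place of 4-hydroxy-3-methoxyphenyl on a double-bonded chain carbon bound to a double-bonded chain carbon. Within the data shown here, no step between measured compounds is available to anchor this change, so the expectation rests on what the two entries show: compound 1, which also carries a 3,4,5-trimethoxyphenyl on its chain, returned no number in this assay. Given that, compound 3 is expected to fall toward weaker inhibition of growth than compound 2, with the step of a 2.4-fold higher number from compound 2 to compound 3 (0.38 log units; beyond the scatter) estimated as larger than the usual scatter, though the record is too thin to be sure. For compound 3 in this assay the estimate is 12000 nM, in a range from 3500 nM to 40000 nM, with a real chance that only an inactive call is reported.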

Compound 3, concentration for 50% growth inhibition: 3050 nM
The estimate for compound 3 lay 3.9-fold (0.59 log units) above the measured number; the whole stated range lies above it.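

In this assay, within the data shown here, putting 3,4,5-trimethoxyphenyl in place of 4-hydroxy-3-methoxyphenyl on a double-bonded chain carbon bound to a double-bonded chain carbon gives a 1.6-fold lower number from compound 2 to compound 3 (0.21 log units; within the scatter), the first step at this position that can be sized, and the loss of the one hydrogen-bond donor of the leaving group comes with no change beyond the scatter. Compound 1 carries the same 3,4,5-trimethoxyphenyl and gives "not active" (no number reported), whereas compound 3 gives 3050 nM, so this group on the chain does not by itself go with an inactive call, although the step between the two cannot be read. Nothing in the data shown accounts for this outcome.

On these data alone, whether a phenyl bearing a carboxylic acid or a dimethylamino group, in place of these two groups on the chain, would move the number beyond the scatter remains open. Also open, as far as these compounds go, is how strongly the aryl group at the other end of the shared core governs growth inhibition, since compound 1 alone differs there and gives no number.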